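This account rests on a few compounds, and the source may have more. Where it says the series, first, only, none or still open, it means among the compounds named here.

Of the compounds shown here, three built on one shared core have been measured in an assay on cells with melanin-concentrating hormone receptor 1 (Homo sapiens) as the target, read by radioligand binding; a lower number here means a stronger inhibitor, a higher number a weaker inhibitor. Compound 1 `CCCC(C)Oc1cccc2ccc(N)nc12` gives 105 nM. Compound 2 `CC(C)C(C)Oc1cccc2ccc(N)nc12` gives 199 nM, and the step of a 1.9-fold higher number from compound 1 to compound 2 (0.28 log units; within the scatter) is small. Compound 3 `CC(C)=CCOc1cccc2ccc(N)nc12` carries the 3-methylbut-2-en-1-yl chain on the oxygen on the aromatic ring; for compound 3 this assay reports only a limit, > 2000 nM. The step of an at least 19-fold higher number from compound 1 to compound 3 (1.27 log units; beyond the scatter) is large, and the step of an at least 10-fold higher number from compound 2 to compound 3 (1.00 log units; beyond the scatter) is also sizeable; both end at the limit (the limit of > 2000 nM in this assay, at which 1 of the 3 values shown sits), so their full size is not known. Among the three, compound 3 is the weakest.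

Compound 4 `CSCCOc1cccc2ccc(N)nc12` has not yet been measured. Its change from compound 3 is this: (methylsulfanyl)methyl in place of 2-methylprop-1-en-1-yl on a saturated chain carbon bound to an oxygen on an aromatic ring. Among the measured compounds shown here, no measured step matches this change directly. What the data do show is that the two steps arriving at compound 3 were both large worsenings, and compound 4 gives up the chain that compound 3 carries, losing its double bond and taking in a sulfur. Compound 4 is therefore expected to move back toward the numbers of compound 1 and compound 2, with an expected step of an at least 2.0-fold lower number from compound 3 to compound 4 (0.30 log units; that floor lies within the scatter), though with wide uncertainty. The estimate for compound 4 in this assay is 1000 nM, ranging between 250 nM and 4000 nM.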

Compound 4, half-maximal inhibitory concentration: > 2000 nM
Compound 4 gave a limit, no number; the forecaster's own chance of this, stated with the estimate: 35%; middle value at least 2.0-fold (0.30 log units) away from the limit.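

Replacing either saturated chain on the oxygen with 2-(methylsulfanyl)ethyl brings a clear loss, an at least 10-fold higher number from compound 2 to compound 4 (1.00 log units; beyond the scatter) and an at least 19-fold higher number from compound 1 to compound 4 (1.27 log units; beyond the scatter). A double bond in the chain is therefore not needed for a loss at this position: compound 4 has none and carries a sulfur instead, yet it also gives no number, and among the four compounds only the 1-methylbutyl and 1,2-dimethylpropyl chains give one. The step between compound 3 and compound 4 cannot be read, and the two cannot be ranked, because both stand at the same limit rather than at a number: the limit of > 2000 nM in this assay, at which 2 of the 4 values shown sit.

The compounds shown leave open how weak compound 3 and compound 4 really are, and whether the loss follows the absence of a methyl on the saturated chain carbon bound to the oxygen or the make-up of the rest of the chain. A plain pentyl chain, or a 2-(methylsulfanyl)ethyl chain carrying that extra methyl, would help to tell these two readings apart.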